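Trifluoromethoxy for fluoro on the amide aryl ring

A few compounds are considered here, and "the series" means these few. Any claim that something is new, unique, unknown or untested is made for them only; others in the source may bear on it.

Measured so far:
compound 1, `O=C(O)CCC(=O)N(C1CC1)[C@H]1c2ccccc2N(C(=O)c2ccc(OC(F)(F)F)cc2)[C@H]2CC[C@H]21`, 4 nM
compound 2, `O=C(O)COC(=O)N(C1CC1)[C@H]1c2ccccc2N(C(=O)c2ccc(F)cc2)[C@H]2CC[C@H]21`, 3.5 nM

Of the compounds shown here, two have been measured in an assay on cells for displacement of a labelled ligand from prostaglandin D2 receptor 2 (Homo sapiens), read by scintillation counting, with a stated time of 60 min; a higher number here means a weaker inhibitor, a lower number a stronger inhibitor. Compound 1 gives 4 nM and compound 2 gives 3.5 nM; the two numbers lie within the scatter of each other, so neither can be called the stronger of the pair. Compound 2 is the one from which the new step starts. Compound 3, `O=C(O)COC(=O)N(C1CC1)[C@H]1c2ccccc2N(C(=O)c2ccc(OC(F)(F)F)cc2)[C@H]2CC[C@H]21`, keeps the core and the carboxymethyl carbamate of compound 2 and changes only the aryl ring: trifluoromethoxy in place of fluoro on an aromatic carbon. For the measured compounds named here, no two measured compounds differ in exactly this one place, so no step of this kind has been observed. Compound 1 carries the same trifluoromethoxy group as compound 3 and still sits close to compound 2 in this assay, which gives little reason to expect a move beyond the scatter. For compound 3 the step of no change at the digits printed from compound 2 to compound 3 (within the scatter) is therefore expected to be small, and its value is estimated at 3.5 nM, within 1.5 nM to 9 nM.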

Compound 3, inhibition constant: 2.5 nM
Estimate against measurement, compound 3: 1.4-fold (0.15 log units) above; the range from low to high includes it.
By their numbers in this assay, from the lowest: compounds 3, 2 and 1 (each within the scatter of the next).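

In this assay, for the compounds shown here, trifluoromethoxy in place of fluoro on an aromatic carbon, para to a large group, gives a 1.4-fold lower number from compound 2 to compound 3 (0.15 log units; within the scatter) and so offers the first direct reading of this change with the rest of the molecule held constant: the five heavy atoms of trifluoromethoxy replace a single fluorine with no shift that can be told from the scatter. With trifluoromethoxy held on the ring, carboxymethoxy in place of 2-carboxyethyl on a carbonyl carbon gives a 1.6-fold lower number from compound 1 to compound 3 (0.20 log units; within the scatter) and likewise cannot be told from the scatter. No other measurement is at hand that bears on these results.

On these data alone, whether an amine or a carboxylic acid at this place on the ring would leave the number equally unmoved remains open. So does the effect of a chain longer than 2-carboxyethyl on the carbonyl carbon.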